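From methoxy to hydroxy on compound 1

The compounds below may be only part of what the source reports. "The series", "measured", "known", "first", "only" and "open" are said of these compounds alone.

Measured in a physicochemical assay, read by spectrophotometry, with a stated time of 30 min; a lower number here means that less compound is needed, a higher number that more compound is needed for the effect:
compound 1 `COc1cccc([C@@H]2Oc3cc(O)cc(O)c3C(=O)[C@H]2O)c1`: > 100000 nM (a limit)
compound 2 `O=C1c2c(O)cc(O)cc2O[C@H](c2c(O)cccc2O)[C@H]1O`: > 100000 nM (a limit)
compound 3 `O=C1c2c(O)cc(O)cc2O[C@@H](c2c(O)cccc2O)[C@@H]1O`: 100000 nM

Compound 1 has no number, only (the limit of > 100000 nM in this assay, at which 2 of the 3 values shown sit). Compound 4 `O=C1c2c(O)cc(O)cc2O[C@@H](c2cccc(O)c2)[C@@H]1O` differs from it by hydrogen in place of methyl on an oxygen on an aromatic ring, methoxy to hydroxy: hydrogen in place of methyl on an oxygen on an aromatic ring. Among the compounds with values here, the one measured step, a number no higher from compound 2 to compound 3 (the limit leaves the size open), has no readable size, and it concerns (the fact that compounds 2 and 3 differ only in the configuration as drawn), so it does not bear directly on this change. Within the data shown here, with compound 3 at 100000 nM as the only number, no step beyond the scatter is expected in this assay. The expected step is a step that the limit leaves unreadable from compound 1 to compound 4. For compound 4 the estimate is 120000 nM, with an expected range from 50000 nM to 300000 nM.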

Compound 4, half-maximal effective concentration: > 100000 nM
Compound 4 gave a limit, no number (the forecaster's own chance of this, stated with the estimate: 65%); the middle value is on the limit's open side.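

In this assay compound 4 gives > 100000 nM, a limit and not a number. Compound 1 also has only a limit, so no step can be read between compound 1 and compound 4. The compounds shown leave open what size of change, if any, methoxy to hydroxy brings in this assay.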